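From compound 2 to a chloro analogue

This account rests on a few compounds, and the source may have more. Where it says the series, first, only, none or still open, it means among the compounds named here.

Compound 1 `CCCCNc1nc2ccc(OC)cc2nc1S(C)(=O)=O`: 20000 nM
Compound 2 `CCCCNc1nc2ccccc2nc1S(C)(=O)=O`: 12600 nM
Compound 3 `COc1ccc2nc(NCC(C)C)c(S(C)(=O)=O)nc2c1`: 12600 nM

All three values come from an ADME assay on HepG2 cells (Homo sapiens) for cytotoxicity, read by CellTiter-Glo, with a stated time of 48 h; on this read-out higher numbers stand for lower toxicity in this test and lower numbers for higher toxicity in this test. In this assay compound 2 gives 12600 nM, and compound 3 gives 12600 nM, the same number at the digits shown. The gap to the third compound is small: the step is a 1.6-fold lower number from compound 1 to compound 2 (0.20 log units; within the scatter).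

Compound 4 `CCCCNc1nc2cc(Cl)ccc2nc1S(C)(=O)=O` has chloro in place of hydrogen on an aromatic carbon of the shared core (chloro in place of hydrogen on an aromatic carbon). For the measured compounds named here, no measured compound carries chloro, so the evidence is indirect. The closest measured change, also on an aromatic carbon, is a 1.6-fold lower number from compound 1 to compound 2 (0.20 log units; within the scatter). The change on the chain bears on it less directly and is a 1.6-fold lower number from compound 1 to compound 3 (0.20 log units; within the scatter). Neither step leaves the scatter, so no shift beyond the scatter is expected, in either direction, in this assay. The estimated step is a 1.1-fold lower number from compound 2 to compound 4 (0.02 log units; within the scatter). For compound 4 the estimated value is 12000 nM, with an expected range from 5500 nM to 25000 nM.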

Compound 4, half-maximal cytotoxic concentration: 6310 nM
The estimate for compound 4 lay 1.9-fold (0.28 log units) above the measured number, and the stated range covers the measured number.
By their numbers in this assay, from the lowest: compounds 4, 2, 3 and 1 (each within the scatter of the next, the first and the last beyond it).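

In this assay, placing chloro on an aromatic carbon, meta to a fused ring and para to a fused ring, gives a 2.0-fold lower number from compound 2 to compound 4 (0.30 log units; within the scatter). For the compounds shown here, the earlier compounds carried only hydrogen or methoxy on the aromatic carbons of the shared core, so this is the first reading for a halogen on that ring, and it shows that this single chlorine atom does not take the number beyond the scatter. No measurement among the data explains this result.

The compounds shown leave open whether a larger or different group on this carbon, such as bromo, trifluoromethyl, an amine or a carboxylic acid, would move the number beyond the scatter. They also leave open whether chloro would give a similar number on another aromatic carbon of the shared core.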